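Swapping an Ester for Trifluoromethyl on the Pendant Ring

This account rests on a few compounds, and the source may have more. Where it says the series, first, only, none or still open, it means among the compounds named here.

Compound 1 `COC(=O)c1cccc(-c2ccc(CN(C)CCN)o2)c1` and compound 2 `COC(=O)c1ccc(-c2ccc(CN(C)CCN)o2)cc1` are built from the same atoms joined differently; the difference between the two cores is not broken down here. In an assay on cells for inhibition of protein arginine N-methyltransferase 1 (Homo sapiens), read by scintillation counting, with stated times of 15 min and 60 min, tested at 9 uM (on this read-out higher numbers stand for more inhibition at the one concentration tested (going by the name of the read-out) and lower numbers for less inhibition), compound 1 gives 38% and compound 2 gives 30%. Compound 3 `CN(CCN)Cc1ccc(-c2cccc(C(F)(F)F)c2)o1` differs from compound 1 by trifluoromethyl in place of methoxycarbonyl on an aromatic carbon and in this assay compound 3 gives 31%, a step of a number 7 percentage points lower from compound 1 to compound 3 (within the scatter). Compound 4 `CN(CCN)Cc1ccc(-c2ccc(C(F)(F)F)cc2)o1` carries the same kind of change relative to compound 2, (trifluoromethyl in place of methoxycarbonyl on an aromatic carbon); the new group sits para to a large group, whereas in compound 3 it sits meta to a large group. Because the earlier step of a number 7 percentage points lower from compound 1 to compound 3 (within the scatter) stayed within the scatter, a similarly small step is expected, a number 6 percentage points lower from compound 2 to compound 4 (within the scatter). Compound 4 is therefore estimated at 24%, with a likely range from 10% to 40%.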

Compound 4, a percentage reported as inhibition, at one concentration (the size of the read-out at that concentration, not a potency): 37%
The estimate for compound 4 lay 13 percentage points below the measured number; low and high end bracket the measured number.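

In this assay, putting trifluoromethyl in place of methoxycarbonyl gives a number 7 percentage points higher from compound 2 to compound 4 (within the scatter). Set beside the same change on the other core, the two steps cannot be told apart: the same change on two cores in this assay, a number 7 percentage points lower (within the scatter) from compound 1 to compound 3 and a number 7 percentage points higher (within the scatter) from compound 2 to compound 4, 14 percentage points apart, within the scatter of two such steps. So on these two cores the change gives no step that stands clear of the scatter, but two pairs cannot show that it would behave the same way on any other core, and the opposite signs of the steps should not be read as a real reversal.

The compounds shown leave open whether another group at this place, such as a nitrile, a carboxylic acid or an amine, would give a step beyond the scatter. They also leave open what a longer chain would do.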